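Bromo to 3-(dimethylamino)phenyl on the shared core

The source may hold more compounds than are shown below. What is called first, only, known or untested is meant among the compounds shown, and "the series" means these compounds.

Compound 1 `Cc1cc(NCc2ccccn2)n2ncc(Br)c2n1` has the highest of the two numbers here: in a physicochemical assay for solubility, read by HPLC, using the shake flask method, measured as kinetic solubility, with a stated time of 2 h, at pH 7.4 (on this read-out lower numbers stand for lower solubility and higher numbers for higher solubility), compound 1 gives 89300 nM. Compound 2 `Cc1cc(NCc2cnccn2)n2nc(C)c(-c3ccccc3)c2n1` carries a phenyl on the core and gives 7100 nM in this assay, a gap beyond the usual scatter. Compound 3 `Cc1cc(NCc2ccc3ccccc3n2)n2nc(C)c(-c3ccccc3)c2n1`, also phenyl-bearing, returns only a limit in this assay, < 5000 nM; the value sits at the limit of < 5000 nM in this assay, at which 1 of the 3 values shown sits. Compound 4 `Cc1cc(NCc2ccccn2)n2ncc(-c3cccc(N(C)C)c3)c2n1` differs from compound 1 by 3-(dimethylamino)phenyl in place of bromo on an aromatic carbon, the same aromatic carbon that holds phenyl in compounds 2 and 3. Going by the values given here, no measured pair isolates this exact change, so the step is an expectation only. Given that compound 2 gives 7100 nM, a step downward beyond the scatter is expected from compound 1 to compound 4, a 6.0-fold lower number from compound 1 to compound 4 (0.77 log units; beyond the scatter). For compound 4 the estimate in this assay is 15000 nM, within 4000 nM to 50000 nM.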

Compound 4, solubility: 94600 nM
Estimate against measurement, compound 4: 6.3-fold (0.80 log units) below; measured number above the stated range.
By their numbers in this assay, from the lowest: compound 2; then compounds 1 and 4 (each within the scatter of the next). At a limit, below all of these: compound 3.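

In this assay, 3-(dimethylamino)phenyl in place of bromo on this aromatic carbon gives a 1.1-fold higher number from compound 1 to compound 4 (0.03 log units; within the scatter). Going by these compounds alone, this is the first step that changes only this position, and it shows that this much larger group, with its six-membered aromatic ring, can sit here with no step beyond the scatter. No measured property on hand bears on this result.

Still open, going by these compounds, is whether this holds for other groups on this carbon, such as a carboxylic acid or a primary amine. Also open, on these data alone, is whether it holds with a different amine side chain on the shared core.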